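Swapping chloro for fluoro and cytotoxicity in rat cells

The source may hold more compounds than are shown below. What is called first, only, known or untested is meant among the compounds shown, and "the series" means these compounds.

Compound 1 `O=C(NN1Cc2ccccc2C1)c1cc([N+](=O)[O-])ccc1F`: > 331000 nM, which is a limit of the assay and not a number.
Compound 2 `O=C(NN1Cc2ccccc2C1)c1cc([N+](=O)[O-])ccc1Cl`: 19800 nM
Compound 3 `O=C(NN(c1ccccc1)c1ccccc1)c1cc([N+](=O)[O-])ccc1Cl`: 13300 nM

All three were tested in an ADME assay on L6 cells (Rattus norvegicus) for cytotoxicity; a lower number here means a stronger inhibitor, a higher number a weaker inhibitor. Compound 2 and compound 1 share one core and differ only in fluoro in place of chloro on an aromatic carbon. That change gave an at least 16-fold higher number from compound 2 to compound 1 (1.22 log units; beyond the scatter). The size of that step is known only as a lower bound because of the limit of > 331000 nM in this assay, at which 1 of the 3 values shown sits.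

Compound 3 has a different core from compound 2; the difference between the two cores is not broken down here. In this assay compound 3 gives 13300 nM, and compound 2 gives 19800 nM, two values within the scatter of each other.

Compound 4 `O=C(NN(c1ccccc1)c1ccccc1)c1cc([N+](=O)[O-])ccc1F` has not yet been measured. It stands to compound 3 exactly as compound 1 stands to compound 2: the only difference is fluoro in place of chloro on an aromatic carbon, the same change as before, at the same place. Since compound 2 and compound 3 give nearly the same number, and the earlier change produced an at least 16-fold higher number from compound 2 to compound 1 (1.22 log units; beyond the scatter), a large rise in the number is expected for compound 4 as well, possibly again up to the limit of this assay. The expected step is a 14-fold higher number from compound 3 to compound 4 (1.13 log units; beyond the scatter). For compound 4 the estimate is 180000 nM, with a likely range from 40000 nM to 600000 nM.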

Compound 4, half-maximal inhibitory concentration: 3200 nM
Compound 4: the middle estimate sits 56-fold (1.75 log units) above what was measured; measured number below the stated range.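

In this assay, fluoro in place of chloro gave a 4.2-fold lower number from compound 3 to compound 4 (0.62 log units; beyond the scatter), so the same change that raised the number on the core of compound 2 lowered it on the core of compound 3, and the two steps point in opposite directions: the same change on two cores in this assay, an at least 16-fold higher number (1.22 log units; beyond the scatter) from compound 2 to compound 1 and a 4.2-fold lower number (0.62 log units; beyond the scatter) from compound 3 to compound 4, at least 69-fold (1.84 log units) apart, beyond the scatter of two such steps

The result of this swap therefore did not carry from one core to the other, even though compound 2 and compound 3 give values within the scatter of each other. It does not show why the two cores respond differently, and the gap between the two steps is known only as a lower bound, since the earlier step rests on a limit of the assay: the limit of > 331000 nM in this assay, at which 1 of the 4 values shown sits.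

With one swap on only two cores, the compounds shown cannot say which way the change would go on a third core, so neither result can be taken as the rule for this series. Going by these compounds, it also remains open whether bromo at the same place, or an amine in place of the nitro group, would split the two cores in the same way.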